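Bromo to hydrogen on the methoxy compound

The compounds below may be only part of what the source reports. "The series", "measured", "known", "first", "only" and "open" are said of these compounds alone.

Values measured in a functional assay on A549 cells (Homo sapiens) for antiproliferative activity, read by MTT assay, with a stated time of 48 h (a lower number here means a stronger inhibitor, a higher number a weaker inhibitor), follow
- compound 1 `Cc1ccc(C(=O)/C=C/c2cc(Br)cc(Br)c2Oc2c([N+](=O)[O-])cc(C(F)(F)F)cc2[N+](=O)[O-])cc1` gives 10.1 ug/mL
- compound 2 `Cc1ccc(C(=O)/C=C/c2cccc(Br)c2Oc2c([N+](=O)[O-])cc(C(F)(F)F)cc2[N+](=O)[O-])cc1` gives 6.85 ug/mL
- compound 3 `COc1ccc(C(=O)/C=C/c2cc(Br)cc(Br)c2Oc2c([N+](=O)[O-])cc(C(F)(F)F)cc2[N+](=O)[O-])cc1` gives 13.2 ug/mL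

Compound 3 sits within the scatter of both compound 1 and compound 2, so the three values set no order. Compound 4 `COc1ccc(C(=O)/C=C/c2cccc(Br)c2Oc2c([N+](=O)[O-])cc(C(F)(F)F)cc2[N+](=O)[O-])cc1` differs from compound 3 by hydrogen in place of bromo on an aromatic carbon and this is hydrogen in place of bromo on an aromatic carbon. The same replacement gave a 1.5-fold lower number from compound 1 to compound 2 (0.17 log units; within the scatter) and the swap of methyl for methoxy gave a 1.3-fold higher number from compound 1 to compound 3 (0.12 log units; within the scatter) so neither measured step leaves the scatter. A step beyond the scatter in this assay is therefore not expected. The estimated change is a 1.5-fold lower number from compound 3 to compound 4 (0.17 log units; within the scatter) and stays within the scatter. For compound 4 the estimate is 9 ug/mL with an expected range from 5.5 ug/mL to 14.5 ug/mL in this series.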

Compound 4, half-maximal inhibitory concentration: 12.7 ug/mL
Compound 4: the middle estimate sits 1.4-fold (0.15 log units) below what was measured, within the range that was stated.
By their numbers in this assay, from the lowest: compounds 2, 1, 4 and 3 (each within the scatter of the next).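

In this assay, hydrogen in place of bromo can now be read on the methoxy core, where it gives a 1.0-fold lower number from compound 3 to compound 4 (0.02 log units; within the scatter), so this position shows no step beyond the scatter on either core: the same change on two cores in this assay, a 1.5-fold lower number (0.17 log units; within the scatter) from compound 1 to compound 2 and a 1.0-fold lower number (0.02 log units; within the scatter) from compound 3 to compound 4, 1.4-fold (0.15 log units) apart, within the scatter of two such steps. Methoxy in place of methyl can also now be read on the core of compound 2, where it gives a 1.9-fold higher number from compound 2 to compound 4 (0.27 log units; within the scatter), and this change likewise stays within the scatter on both cores: the same change on two cores in this assay, a 1.3-fold higher number (0.12 log units; within the scatter) from compound 1 to compound 3 and a 1.9-fold higher number (0.27 log units; within the scatter) from compound 2 to compound 4, 1.4-fold (0.15 log units) apart, within the scatter of two such steps.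

At this position, the compounds shown compare only bromo and hydrogen. As far as these compounds go, whether an amine or a carboxylic acid here would give a step beyond the scatter remains open.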